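Swapping Amino for Methylcarbamoyl on the Sulfonate Ester Ring

The source may report more compounds than this note shows. Statements on the series, on what has been measured and on what is new or still open speak of the compounds shown alone.

Compound 3 `Nc1cccc(S(=O)(=O)Oc2ccc(-c3cncn3C3CCN(C(=O)c4ccc(Cl)c(C(F)(F)F)c4)CC3)cc2)c1` is the only one of the three measured compounds to give a number in an assay on HEK293 cells for antagonist activity at P2X purinoceptor 7 (Homo sapiens), read by fluorescence, with a stated time of 2 h (a lower number here means a stronger inhibitor, a higher number a weaker inhibitor), at 565 nM. Compound 1 `O=C(Oc1ccc(-c2cncn2C2CCN(C(=O)c3ccc(Cl)c(C(F)(F)F)c3)CC2)cc1)c1cccc2cnccc12` sits at a limit of the assay, > 10000 nM. Compound 2 `CC(=O)Oc1ccc(-c2cncn2C2CCN(C(=O)c3ccc(Cl)c(C(F)(F)F)c3)CC2)cc1` likewise sits at a limit, > 10000 nM. Two of the three values thus fall at the limit of > 10000 nM in this assay, at which 2 of the 3 values shown sit. The two readable steps both point the same way: an at least 17-fold lower number from compound 1 to compound 3 (1.24 log units; beyond the scatter) and an at least 17-fold lower number from compound 2 to compound 3 (1.24 log units; beyond the scatter), so the (3-aminophenyl)sulfonyl ester stands apart from the two carboxylate esters. Compound 4 `CNC(=O)c1cccc(S(=O)(=O)Oc2ccc(-c3cncn3C3CCN(C(=O)c4ccc(Cl)c(C(F)(F)F)c4)CC3)cc2)c1` keeps that sulfonate ester and alters only its ring: methylcarbamoyl in place of amino on an aromatic carbon. Among the compounds with values here, no measured step varies the substituent on this ring, so nothing among the measured compounds bears directly on the size of this step. Compound 4 is therefore expected to change little, a step of a 1.2-fold higher number from compound 3 to compound 4 (0.09 log units; within the scatter) in this assay. The estimate for compound 4 is 700 nM, within 200 nM to 3000 nM.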

Compound 4, half-maximal inhibitory concentration: 112 nM
The estimate for compound 4 lay 6.3-fold (0.80 log units) above the measured number, outside the stated range (below it).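

In this assay, within the data shown here, methylcarbamoyl in place of amino on the aromatic carbon gives a 5.0-fold lower number from compound 3 to compound 4 (0.70 log units; beyond the scatter) and so shows that the substituent on the sulfonate ester ring is not indifferent, a point the earlier steps could not reach, as they changed the whole group on the oxygen. Amino is thus not needed at this place, and methylcarbamoyl in its stead goes with a stronger inhibitor. Nothing shown on a measured property of these groups bears on this step.

Which part of methylcarbamoyl goes with the step stays open: a primary carboxamide, a carboxylic acid or ethylcarbamoyl on this ring would separate them. Also open, from the compounds shown here alone, is whether a sulfonamide in place of the sulfonate ester would keep the number of compound 4.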